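Compound 3 to compound 4: pyridin-4-yl leaves the chain

This account rests on a few compounds, and the source may have more. Where it says the series, first, only, none or still open, it means among the compounds named here.

Measured so far in an ADME assay on A549 cells (Homo sapiens) for cytotoxicity, read by resazurin assay, with a stated time of 48 h (a lower number here means that less compound is tolerated, a higher number that more compound is tolerated), for three compounds
compound 1 `COc1ccc(CNc2ccc(NC(=O)c3cc(Cl)ccc3O)c(Cl)c2)cc1` gives 80700 nM
compound 2 `CN(C)c1ccc(CNc2ccc(NC(=O)c3cc(Cl)ccc3O)c(Cl)c2)cc1` gives 24500 nM
compound 3 `O=C(Nc1ccc(NCc2ccncc2)cc1Cl)c1cc(Cl)ccc1O` gives 65300 nM

Compound 3 cannot be told apart from compound 1 (a 1.2-fold lower number from compound 1 to compound 3 (0.09 log units; within the scatter)). Compound 2 alone stands apart from the other two, by modest steps (a 3.3-fold lower number from compound 1 to compound 2 (0.52 log units; beyond the scatter); a 2.7-fold higher number from compound 2 to compound 3 (0.43 log units; beyond the scatter)).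

Compound 4 `CC(C)(C)OC(=O)NCCNc1ccc(NC(=O)c2cc(Cl)ccc2O)c(Cl)c1` keeps the shared core and carries ((tert-butoxycarbonyl)amino)methyl in place of pyridin-4-yl on a saturated chain carbon bound to a nitrogen on an aromatic ring. The two ring exchanges at this place are the closest guides. One lay within the scatter (a 1.2-fold lower number from compound 1 to compound 3 (0.09 log units; within the scatter)) and the other was modest (a 2.7-fold higher number from compound 2 to compound 3 (0.43 log units; beyond the scatter)). Neither of them removes the ring from this place, so they guide the present change only weakly and the range has to stay wide. In this assay, going by these compounds, no step beyond the scatter is expected, and the direction remains open. The expected step is small (a 1.3-fold lower number from compound 3 to compound 4 (0.12 log units; within the scatter)). Compound 4 is estimated at 50000 nM (range 18000 nM to 120000 nM).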

Compound 4, half-maximal cytotoxic concentration: 25000 nM
Compound 4: middle estimate off by 2.0-fold (0.30 log units), on the high side; the range from low to high includes it.
By their numbers in this assay, from the lowest: compounds 2 and 4 (each within the scatter of the next); then compounds 3 and 1 (each within the scatter of the next).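

In this assay, the exchange of pyridin-4-yl for ((tert-butoxycarbonyl)amino)methyl is the first change shown that removes the ring from this place on a saturated chain carbon bound to a nitrogen on an aromatic ring, and it gives a step beyond the scatter (a 2.6-fold lower number from compound 3 to compound 4 (0.42 log units; beyond the scatter)). A group with no ring reaches the same level as the 4-(dimethylamino)phenyl group, as compound 4 cannot be told apart from compound 2 (a 1.0-fold higher number from compound 2 to compound 4 (0.01 log units; within the scatter)), while it stays apart from the 4-methoxyphenyl group (a 3.2-fold lower number from compound 1 to compound 4 (0.51 log units; beyond the scatter)), so a ring at this place is not required for a number at this lower level. No measurement at hand bears on what lies behind these steps.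

With only one ringless group shown, the step from compound 3 cannot be divided between the departure of pyridin-4-yl and the arrival of the tert-butoxycarbonyl group on the chain. Going by these compounds, whether the lower number stays with the chain or goes with that group remains open, and an aminomethyl group with a free primary amine, a carboxylic acid or a longer chain at the same place would test this.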